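The compounds below may be only part of what the source reports. "The series", "measured", "known", "first", "only" and "open" are said of these compounds alone.

Three compounds share one core and differ only in the aromatic group attached to the sulfonyl sulfur. In a functional assay on the whole organism (strain Kunming) for inhibition, with Mus musculus as the target, with a stated time of 1 h, at a dose of 40 mg/kg by the oral route (on this read-out lower numbers stand for less inhibition and higher numbers for more inhibition at the one dose given (going by the name of the read-out)), compound 1 `O=C(/C=C/c1ccccc1)c1ccc(N2CCN(S(=O)(=O)c3ccc(Cl)cc3)CC2)cc1` gives 46.8%. Compound 2 `O=C(/C=C/c1ccccc1)c1ccc(N2CCN(S(=O)(=O)c3ccc4ccccc4c3)CC2)cc1` carries naphthalen-2-yl in place of 4-chlorophenyl, and in this assay compound 2 gives 35%, which is a number 11.8 percentage points lower from compound 1 to compound 2 (beyond the scatter). Compound 3 `O=C(/C=C/c1ccccc1)c1ccc(N2CCN(S(=O)(=O)c3ccc(OC(F)(F)F)cc3)CC2)cc1` carries trifluoromethoxy in place of chloro on an aromatic carbon, and in this assay compound 3 gives 47.4%. That is a number 0.6 percentage points higher from compound 1 to compound 3 (within the scatter), but a number 12.4 percentage points higher from compound 2 to compound 3 (beyond the scatter). Compound 3 thus holds the largest number of the three, though compound 1 sits within the usual scatter of it and only compound 2 lies clearly lower.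

Compound 4 `O=C(/C=C/c1ccccc1)c1ccc(N2CCN(S(=O)(=O)c3ccc(C(F)(F)F)cc3)CC2)cc1` has not yet been measured. It differs from compound 3 in one place: trifluoromethyl in place of trifluoromethoxy on an aromatic carbon. The step that bears most on this is the exchange of chloro for trifluoromethoxy, which moved the number only a number 0.6 percentage points higher from compound 1 to compound 3 (within the scatter). The changes that went beyond the scatter, a number 11.8 percentage points lower from compound 1 to compound 2 (beyond the scatter) and a number 12.4 percentage points higher from compound 2 to compound 3 (beyond the scatter), both exchanged a whole ring for a single-ring group rather than one small group for another. A small group exchanged for another small group at the same place is therefore expected to leave this assay nearly unchanged, with no step beyond the scatter. For compound 4 the estimate is 46%, between 34% and 58%. The expected step is a number 1.4 percentage points lower from compound 3 to compound 4 (within the scatter).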

Compound 4, a percentage reported as inhibition, in the whole organism at one dose (the size of the read-out at that dose, not a potency): 47.9%
Beside the measured number, compound 4's estimate is 1.9 percentage points below it; measured number inside the range.
By their numbers in this assay, from the lowest: compound 2; then compounds 1, 3 and 4 (each within the scatter of the next).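

Within this assay, trifluoromethyl in place of trifluoromethoxy on the six-membered aromatic ring gives a number 0.5 percentage points higher from compound 3 to compound 4 (within the scatter), so at this dose the read-out does not depend on keeping the oxygen of trifluoromethoxy, the hydrogen-bond acceptor counted in that group. Chloro at the same place tells the same story, as trifluoromethyl in its place gives a number 1.1 percentage points higher from compound 1 to compound 4 (within the scatter), and the three small groups of compound 1, compound 3 and compound 4 now all lie within the scatter of one another. The naphthalen-2-yl group stays the one clear departure among these compounds, since 4-(trifluoromethyl)phenyl in its place gives a number 12.9 percentage points higher from compound 2 to compound 4 (beyond the scatter), which shows that a change of the whole aromatic group has moved this read-out while changes of the small group on the single ring have not.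

On these data alone, it remains open whether a group of a different kind at this place, such as an amine, a carboxylic acid or a longer chain, would also leave the read-out where it stands. Why the three small groups read alike also stays open, as nothing measured here speaks to it.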